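The compounds below may be only part of what the source reports. "The series", "measured", "known", "first", "only" and "open" are said of these compounds alone.

Of the compounds shown here, two have been measured in a physicochemical assay for lipophilicity; on this read-out lower numbers stand for lower lipophilicity and higher numbers for higher lipophilicity. Compound 1, `CC1(C)CC(NC(=O)C(C)(C)/C=C/[C@H](NC(=O)OC(C)(C)C)c2ccccc2)CC(C)(C)N1`, gives 4.2 in this assay. Compound 2, `CC(C)C[C@@H](/C=C/C(C)(C)C(=O)NC1CC(C)(C)NC(C)(C)C1)NC(=O)OC(C)(C)C`, gives 4 in this assay, the lower of the two numbers, and its nearest neighbour is compound 1, whose number lies higher by an amount that stays within the usual scatter of repeated measurements, so the two values cannot be told apart.

The step now followed leads from compound 2 to compound 3, `CC(C)C[C@H](/C=C/C(C)(C)C(=O)NC1CC(C)(C)NC(C)(C)C1)NC(=O)OC(C)(C)C`. The structural change is the two compounds have the same atoms and bonds and differ only in configuration as drawn: 1 of 2 stereo elements differ; a stereocentre at a saturated chain carbon is drawn S in compound 2 and R in compound 3. No measured pair in this set separates two compounds in this way, so the size of the step is not shown by any earlier comparison. Since the two compounds share every atom and bond, no step beyond the scatter is expected in this assay in either direction. For compound 3 the value in this assay is therefore expected to be 4, with a range from 3.7 to 4.3, which means an expected step of no change at the digits printed from compound 2 to compound 3 (within the scatter) of essentially nothing.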

Compound 3, partition coefficient: 4
Beside the measured number, compound 3's estimate shows no gap at the digits printed; the range from low to high includes it.
By their numbers in this assay, from the lowest: compounds 2, 3 and 1 (each within the scatter of the next).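

In this assay, among the compounds shown here, the first comparison of two drawn configurations at this saturated chain carbon gives no change at the digits printed from compound 2 to compound 3 (within the scatter). With the R configuration drawn at this position, isobutyl in place of phenyl gives a number 0.20 log units lower from compound 1 to compound 3 (within the scatter), so neither step separates the compounds on this read-out. The result for the configurational pair sits with a single structural fact: the fact that compounds 2 and 3 differ only in the configuration as drawn

The compounds shown leave open whether a different group on this carbon, such as an amine, a carboxylic acid or a longer chain, would give a step beyond the scatter in this assay. They also leave open whether the two configurations would read alike with phenyl on this carbon, as they do here with isobutyl.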